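This account rests on a few compounds, and the source may have more. Where it says the series, first, only, none or still open, it means among the compounds named here.

Measured so far:
- compound 1, `Cc1ccc(C2CC(=O)c3ccc(F)cc3O2)cc1`: 160 nM
- compound 2, `Cc1ccc([C@@H]2CC(=O)c3ccc(C)cc3O2)cc1`: 590 nM
- compound 3, `Cc1ccc([C@H]2CC(=O)c3ccc(F)cc3O2)cc1`: 150 nM

Among these three numbers in an in vitro assay on BTI-TN-5B1-4 cells for inhibition of Amine oxidase [flavin-containing] B (Homo sapiens) (a higher number here means a weaker inhibitor, a lower number a stronger inhibitor), compound 3 gives 150 nM, the lowest; compound 1 lies nearest, with a 1.1-fold lower number from compound 1 to compound 3 (0.03 log units; within the scatter) between them, while compound 2 stands furthest away at 590 nM. Compound 4, `Cc1ccc([C@@H]2CC(=O)c3ccc(F)cc3O2)cc1`, has not yet been measured. It differs from compound 3 in this way: the two compounds have the same atoms and bonds and differ only in configuration as drawn: 1 of 1 stereo elements differ; a stereocentre at a saturated ring carbon is drawn R in compound 3 and S in compound 4. Going by the values given here, the only measured step that bears on configuration at that ring carbon is the one from compound 1 to compound 3, which was a 1.1-fold lower number from compound 1 to compound 3 (0.03 log units; within the scatter); because of the fact that one of compounds 1 and 3 is drawn with a defined configuration and the other without, at the place where they differ, that step sets a mixture beside one defined enantiomer rather than one enantiomer beside the other, so it gives only an indirect hint. That hint is that the other configuration is not far behind, so compound 4 is expected to show a modest rise in this assay, by a 1.9-fold higher number from compound 3 to compound 4 (0.27 log units; within the scatter). The estimate for compound 4 is 280 nM, with a range from 90 nM to 1200 nM.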

Compound 4, half-maximal inhibitory concentration: 150 nM
The estimate for compound 4 lay 1.9-fold (0.27 log units) above the measured number, within the range that was stated.
By their numbers in this assay, from the lowest: compounds 3, 4 and 1 (each within the scatter of the next); then compound 2.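

In this assay, the configuration at the saturated ring carbon, now compared directly, has no visible effect, with no change at the digits printed from compound 3 to compound 4 (within the scatter): the fact that compounds 3 and 4 differ only in the configuration as drawn. The form drawn without a configuration gives a matching result, with a 1.1-fold lower number from compound 1 to compound 4 (0.03 log units; within the scatter), so at this ring carbon neither the R nor the S form stands apart from it: the fact that one of compounds 1 and 4 is drawn with a defined configuration and the other without, at the place where they differ. With the S configuration drawn in both compounds, fluoro in place of methyl on an aromatic carbon can now be read as a single change, giving a 3.9-fold lower number from compound 2 to compound 4 (0.59 log units; beyond the scatter), and among these compounds only this change moves the number beyond the scatter.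

The compounds shown leave open whether configuration at the ring carbon would matter as little with methyl in place of fluoro on the aromatic carbon. They also leave open how a chloro group, an amine or a carboxylic acid there would read.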